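The source may report more compounds than this note shows. Statements on the series, on what has been measured and on what is new or still open speak of the compounds shown alone.

The compounds measured so far, with their values in a functional assay on MGC-803 cells (Homo sapiens) for inhibition, read by MTT assay, with a stated time of 72 h; a higher number here means a weaker inhibitor, a lower number a stronger inhibitor:

compound 1, `C=CC(=O)Nc1cccc(NC(=O)CSc2nc(Nc3ccccc3)c3ccccc3n2)c1`, gives 7310 nM
compound 2, `C=CC(=O)Nc1cccc(NC(=O)CSc2nc(Nc3ccccc3F)c3ccccc3n2)c1`, gives 26100 nM
compound 3, `C=CC(=O)Nc1cccc(NC(=O)CSc2nc(Nc3cccc(Cl)c3)c3ccccc3n2)c1`, gives 7830 nM

Compound 3 stands second highest of these three numbers. Its nearest neighbour is compound 1, with a 1.1-fold higher number from compound 1 to compound 3 (0.03 log units; within the scatter), a gap within the usual scatter, so the two are indistinguishable here. Compound 2 stands furthest away, with a 3.3-fold lower number from compound 2 to compound 3 (0.52 log units; beyond the scatter).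

Compound 4, `C=CC(=O)Nc1cccc(NC(=O)CSc2nc(Nc3cccc(C)c3)c3ccccc3n2)c1`, differs from compound 3 in one place: methyl in place of chloro on an aromatic carbon. Within the data shown here, no measured pair makes exactly this swap, so the guide has to come from nearby steps. The step from compound 1 to compound 3, a 1.1-fold higher number from compound 1 to compound 3 (0.03 log units; within the scatter), shows that putting chloro at this position changed nothing beyond the scatter. Among the measured compounds shown here, the one step that moved the number, a 3.6-fold higher number from compound 1 to compound 2 (0.55 log units; beyond the scatter), concerns a different group at a different place on the same ring and does not speak directly to this exchange.

With chloro already behaving like hydrogen at this position, a small methyl in its place is expected to leave the number where it is: the expected step is a 1.0-fold higher number from compound 3 to compound 4 (0.01 log units; within the scatter), within the scatter. Compound 4 is therefore estimated at 8000 nM in this assay, with a range from 3500 nM to 18000 nM.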

Compound 4, half-maximal inhibitory concentration: 20900 nM
Estimate against measurement, compound 4: 2.6-fold (0.42 log units) below; the measured number lies above the stated range.
By their numbers in this assay, from the lowest: compounds 1 and 3 (each within the scatter of the next); then compounds 4 and 2 (each within the scatter of the next).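

Chloro and methyl each bring one heavy atom and no hydrogen-bond donors or acceptors, yet exchanging them at this place on the ring gives a 2.7-fold higher number from compound 3 to compound 4 (0.43 log units; beyond the scatter) in this assay, and methyl in place of hydrogen gives a 2.9-fold higher number from compound 1 to compound 4 (0.46 log units; beyond the scatter), so this position is not indifferent to what it carries, as chloro alone had suggested. The change from 2-fluorophenyl to 3-methylphenyl gives a 1.2-fold lower number from compound 2 to compound 4 (0.10 log units; within the scatter), so two different substitutions on this ring now give numbers that cannot be told apart, while hydrogen and chloro at the 3-position stay together at the lower end. Nothing measured here explains why methyl and chloro part at this position.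

Because fluoro and methyl sit at different places on the ring, these compounds cannot separate the effect of the group from the effect of its place, and fluoro at the place held by chloro and methyl would be the direct test. From the compounds shown here alone, it also remains open whether a methoxy group, an amine or a longer chain such as ethyl at this same place would track with chloro or with methyl.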